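Cyano to acetyl on compound 3

This account rests on a few compounds, and the source may have more. Where it says the series, first, only, none or still open, it means among the compounds named here.

In a functional assay on NALM-6 cells (Homo sapiens) for cytotoxicity, with a stated time of 72 h (a lower number here means that less compound is needed, a higher number that more compound is needed for the effect), compound 1 `C=C[C@@](C)(/C=C/c1ccc(O)c(/C=C/C#N)c1)CCC=C(C)C` reaches only a limit, > 43400 nM. Compound 2 `C=C[C@@](C)(/C=C/c1ccc(O)c(/C=C/c2ccc(F)cc2)c1)CCC=C(C)C` also reaches only a limit, > 43400 nM. Compound 3 `COc1ccc(/C=C/[C@@](C)(/C=C/c2ccc(O)c(/C=C/C#N)c2)CCC=C(C)C)cc1` alone gives an actual number, 16500 nM. Compound 4 `COc1ccc(/C=C/[C@@](C)(/C=C/c2ccc(O)c(/C=C/C(C)=O)c2)CCC=C(C)C)cc1` carries acetyl in place of cyano on a double-bonded chain carbon bound to a double-bonded chain carbon. Among the measured compounds shown here, the one measured change at this place, a step that the two limits leave unreadable from compound 1 to compound 2, has no readable size. The other measured change, an at least 2.6-fold lower number from compound 1 to compound 3 (0.42 log units; beyond the scatter), brought in the 2-(4-methoxyphenyl)ethenyl group, and compound 4 keeps that group. With no readable guide at this place, the expectation is a 1.0-fold lower number from compound 3 to compound 4 (0.01 log units; within the scatter), no step beyond the scatter. Compound 4 is estimated at 16000 nM, with an expected range from 6000 nM to 43000 nM.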

Compound 4, half-maximal effective concentration: > 43400 nM
Compound 4: only a limit was reported; the forecaster's own chance of this, stated with the estimate: 25%; middle value at least 2.7-fold (0.43 log units) from the limit.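

At this place, on a double-bonded chain carbon bound to a double-bonded chain carbon, the change matters: in this assay, acetyl in place of cyano gives an at least 2.6-fold higher number from compound 3 to compound 4 (0.42 log units; beyond the scatter). Among the compounds shown here, the earlier change at this place could not be read, so this is the first readable step here, and the measurable number gained with the 2-(4-methoxyphenyl)ethenyl group does not survive it. The true size of the step stays unknown because compound 4 reaches only a limit: the limit of > 43400 nM in this assay, at which 3 of the 4 values shown sit.

From the compounds shown here alone, whether an amide or a carboxylic acid at this place would keep a measurable number remains open. So does the effect of 4-fluorophenyl here when the 2-(4-methoxyphenyl)ethenyl group is present.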